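A Methoxy Group Moved Around the Benzyl Ring

The source may report more compounds than this note shows. Statements on the series, on what has been measured and on what is new or still open speak of the compounds shown alone.

Compound 3 `COc1ccccc1COc1ccccc1OCCNCCOc1c(OC)cccc1OC` gives 2 nM in an assay on CHO cells for displacement of a labelled ligand from Alpha-1D adrenergic receptor (Homo sapiens) (a lower number here means a stronger inhibitor, a higher number a weaker inhibitor), the highest number among the three compounds measured. Compound 1 `COc1cccc(OC)c1OCCNCCOc1ccccc1OCc1ccccc1C` gives 0.126 nM in this assay, and compound 2 `COc1cccc(OC)c1OCCNCCOc1ccccc1OCc1cccc([N+](=O)[O-])c1` gives 0.0631 nM. The steps of a 16-fold higher number from compound 1 to compound 3 (1.20 log units; beyond the scatter) and a 32-fold higher number from compound 2 to compound 3 (1.50 log units; beyond the scatter) show that the group carried on the phenyl of the benzyl ether sets the number over a wide span, whereas a 2.0-fold lower number from compound 1 to compound 2 (0.30 log units; within the scatter) stays within the scatter. Compound 4 `COc1ccc(COc2ccccc2OCCNCCOc2c(OC)cccc2OC)cc1` differs from compound 3 by 4-methoxyphenyl in place of 2-methoxyphenyl on a saturated chain carbon bound to an oxygen on an aromatic ring. Going by the values given here, no measured pair shifts the same group from one ring position to another, so none of the steps speaks directly to this change. What the data do show is that compound 3 carries the one substituent pattern on that ring giving a clearly higher number than either alternative, so a lower number for compound 4 is expected, with its size uncertain. Compound 4 is therefore estimated at 0.6 nM, with a range from 0.1 nM to 4 nM, which means an expected step of a 3.3-fold lower number from compound 3 to compound 4 (0.52 log units; beyond the scatter).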

Compound 4, inhibition constant: 0.1 nM
Compound 4: middle estimate off by 6.0-fold (0.78 log units), on the high side, within the range that was stated.
By their numbers in this assay, from the lowest: compounds 2, 4 and 1 (each within the scatter of the next); then compound 3.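

With the same atoms joined differently, the swap of 2-methoxyphenyl for 4-methoxyphenyl gives a 20-fold lower number from compound 3 to compound 4 (1.30 log units; beyond the scatter) in this assay, the first measured case in which only the place of a methoxy on this ring changes the number. The other two steps, a 1.6-fold higher number from compound 2 to compound 4 (0.20 log units; within the scatter) and a 1.3-fold lower number from compound 1 to compound 4 (0.10 log units; within the scatter), stay within the scatter, so 4-methoxyphenyl, 3-nitrophenyl and 2-methylphenyl cannot be told apart here. Among these four compounds the higher number goes with 2-methoxyphenyl alone, and a methoxy on this ring does not bring it in compound 4.

From the compounds shown here alone, whether 3-methoxyphenyl would sit with compound 3 or compound 4, and whether 2-ethoxyphenyl or 2-hydroxyphenyl would also give a higher number, remains open. Nothing in the available data accounts for the large step from the 2-methoxyphenyl compound.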